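A few compounds are considered here, and "the series" means these few. Any claim that something is new, unique, unknown or untested is made for them only; others in the source may bear on it.

Compound 1 `O=C(Nc1cccc(-n2cc(-c3ccncc3)c(-c3ccc(Cl)c(O)c3)n2)c1)Nc1cccc(C(F)(F)F)c1` gives 948 nM in a functional assay on PC-3 cells (Homo sapiens) for inhibition, read by sulforhodamine B assay, with a stated time of 48 h (a lower number here means a stronger inhibitor of growth, a higher number a weaker inhibitor of growth), and compound 2 `O=C(Nc1cccc(-n2cc(-c3ccncc3)c(-c3ccc(Cl)c(O)c3)n2)c1)Nc1ccc(Cl)c(Cl)c1` gives 834 nM; the step of a 1.1-fold lower number from compound 1 to compound 2 (0.06 log units; within the scatter) lies within the scatter. Compound 3 `COc1cc(-c2nn(-c3cccc(NC(=O)Nc4ccc(Cl)c(C(F)(F)F)c4)c3)cc2-c2ccncc2)ccc1Cl` gives 690 nM, standing nearest compound 2 and furthest from compound 1, both gaps within the scatter, so no order among the three can be claimed. Compound 4 `O=C(Nc1cccc(-n2cc(-c3ccncc3)c(-c3ccc(Cl)c(O)c3)n2)c1)Nc1ccc(Cl)c(C(F)(F)F)c1` differs from compound 3 by hydrogen in place of methyl on an oxygen on an aromatic ring. Among the measured compounds shown here, no measured step covers a change on this oxygen; compounds 1 and 2 carry the hydroxy group, compound 3 the methoxy group, and all three values sit together. A step of a 1.2-fold higher number from compound 3 to compound 4 (0.06 log units; within the scatter) within the scatter is therefore expected. Compound 4 is estimated at 800 nM, range 400 nM to 1600 nM.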

Compound 4, concentration for 50% growth inhibition: 5880 nM
Compound 4: the middle estimate sits 7.4-fold (0.87 log units) below what was measured; measured number outside the range, above it.
By their numbers in this assay, from the lowest: compounds 3, 2 and 1 (each within the scatter of the next); then compound 4.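

In this assay, the change from methoxy to hydroxy on the aromatic ring is not silent: an 8.5-fold higher number from compound 3 to compound 4 (0.93 log units; beyond the scatter). With hydroxy held constant, the aryl group on the other urea nitrogen also matters, with a 6.2-fold higher number from compound 1 to compound 4 (0.79 log units; beyond the scatter) and a 7.1-fold higher number from compound 2 to compound 4 (0.85 log units; beyond the scatter), whereas a 1.1-fold lower number from compound 1 to compound 2 (0.06 log units; within the scatter) showed no such separation. Nothing given here explains these steps.

Still open, on these data alone, is whether an amine or an ethoxy group on this aromatic carbon would track with hydroxy or methoxy. Also open, as far as these compounds go, is how methoxy behaves alongside the aryl groups of compound 1 and compound 2.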